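Oxime in place of acetyl on an anilide chain

The compounds below may be only part of what the source reports. "The series", "measured", "known", "first", "only" and "open" are said of these compounds alone.

Measured compounds:
compound 1 `O=C(CCCCCCNC(=O)C(O)(O)C(F)(F)F)Nc1nc2ccc(Cl)cc2s1`, 11000 nM
compound 2 `CC(=O)C(=O)NCCCCC(=O)Nc1ccccc1`, > 100000 nM

In a functional assay on HCT-116 cells (Homo sapiens) for inhibition, read by colorimetric assay, with a stated time of 3 days (on this read-out lower numbers stand for stronger inhibition and higher numbers for weaker inhibition), compound 1 gives 11000 nM. Compound 2 gives only a limit in this assay, > 100000 nM, so no number is known for it. Compound 2 stands where (the limit of > 100000 nM in this assay, at which 1 of the 2 values shown sits), and so its place among the measured values is only that it is no stronger than that limit.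

Compound 3 `C/C(=N\O)C(=O)NCCCCC(=O)Nc1ccccc1` has not yet been measured in this assay. It differs from compound 2 at one place (a group of 4 heavy atoms (2 carbon, 1 nitrogen, 1 oxygen; no ring) in place of a group of 3 heavy atoms (2 carbon, 1 oxygen; no ring), on a carbonyl carbon). The change sits on a carbonyl carbon whose other neighbours are an amide-type nitrogen, and the whole remaining chain and the anilide end are kept.

Compound 2 offers no measured number from which a direction could be taken, and the step from compound 1 to compound 2 is not a single change. Compound 3 is therefore expected to stay close to where compound 2 stands, with the step that the limit leaves unreadable from compound 2 to compound 3 expected to be small in either direction. For compound 3 the estimate is 150000 nM in this assay, within a range from 40000 nM to 500000 nM.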

Compound 3, half-maximal inhibitory concentration: > 100000 nM
Compound 3 was reported as a limit (the forecaster's own chance of this, stated with the estimate: 75%); the middle value does not contradict the limit.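

Compound 2 and compound 3 each give only a limit rather than a number, so the step between them cannot be read: the limit of > 100000 nM in this assay, at which 2 of the 3 values shown sit.

The compounds shown leave open whether the group of 4 heavy atoms in place of acetyl changes inhibition in this assay at all, in either direction.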